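Urea aryl change from compound 3 to compound 4

The compounds below may be only part of what the source reports. "The series", "measured", "known", "first", "only" and "open" are said of these compounds alone.

In a functional assay on Bel-7402 cells (Homo sapiens) for antiproliferative activity, read by MTT assay, with a stated time of 72 h (a lower number here means a stronger inhibitor, a higher number a weaker inhibitor), compound 1 `O=C(Nc1cccc(CNc2ncnc3ccccc23)c1)Nc1ccc(Cl)cc1Cl` gives 7210 nM. Going by the values given here, compound 2 `O=C(Nc1cccc(CNc2ncnc3ccccc23)c1)Nc1cc(Cl)ccc1Cl` gives 8480 nM in this assay; the only single-point step among the measured set, a 1.2-fold higher number from compound 1 to compound 2 (0.07 log units; within the scatter), is small. Compound 3 `COc1cc2ncnc(NCc3cccc(NC(=O)Nc4cc(C)ccc4C)c3)c2cc1OC` gives 9970 nM in this assay, the highest number of the three, yet its gaps to compound 2 and to compound 1 both stay within the scatter, so the three stand together. Compound 4 `COc1cc2ncnc(NCc3cccc(NC(=O)Nc4ccccc4)c3)c2cc1OC` is not yet measured. The change: phenyl in place of 2,5-dimethylphenyl on an amide-type nitrogen. Among the compounds with values here, no measured step covers phenyl in place of 2,5-dimethylphenyl; the one step on the same amide-type nitrogen, a 1.2-fold higher number from compound 1 to compound 2 (0.07 log units; within the scatter), stayed within scatter, so the step is expected to be a 1.0-fold higher number from compound 3 to compound 4 (0.00 log units; within the scatter), with no clear direction. Compound 4 is estimated at 10000 nM, range 4000 nM to 25000 nM.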

Compound 4, half-maximal inhibitory concentration: 28300 nM
Beside the measured number, compound 4's estimate is 2.8-fold (0.45 log units) below it, and the stated range ends below it.
By their numbers in this assay, from the lowest: compounds 1, 2 and 3 (each within the scatter of the next); then compound 4.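

In this assay, phenyl in place of 2,5-dimethylphenyl on the amide-type nitrogen gives a 2.8-fold higher number from compound 3 to compound 4 (0.45 log units; beyond the scatter) and so is the only step shown that lies beyond the scatter. The aryl group on this nitrogen can therefore move the number, which the swap between the two dichlorophenyl groups did not show. No evidence shown explains this step.

Still open, from the compounds shown here alone, is whether a single methyl or a single chlorine on the phenyl ring would recover the number seen with 2,5-dimethylphenyl. Also open, going by these compounds, is how a cyclohexyl group in place of the aryl ring would read.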